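Fused-ring amine series: acid dissociation notes

The source may hold more compounds than are shown below. What is called first, only, known or untested is meant among the compounds shown, and "the series" means these compounds.

Measured so far:
Compound 1, `COc1ccc(F)cc1CNCCCNc1ccnc2cc(C3CCCCC3)ccc12`: in a physicochemical assay for acid dissociation, compound 1 gives 9.47.
Compound 2, `c1coc(CNCCCNc2ccnc3cc(C4CCCCC4)ccc23)c1`: in this assay compound 2 gives 9.47.

Compound 1 stands level with compound 2 at the digits shown; the single measured step, no change at the digits printed from compound 1 to compound 2 (within the scatter), replaces the group on the saturated chain carbon bound to an amine nitrogen and leaves the read-out unchanged within the scatter.

Compound 3, `COc1ccc(F)cc1CNCCCNc1ccnc2cc(Oc3ccccc3OC)ccc12`, is not yet measured. It differs from compound 1 at another site: 2-methoxyphenoxy in place of cyclohexyl on an aromatic carbon.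

Among the measured compounds shown here, no measured step touches the aromatic carbon of the shared core, so there is no direct precedent for this change. For the measured compounds named here, the one step available, no change at the digits printed from compound 1 to compound 2 (within the scatter), shows that a change away from the fused ring system left the value flat. On that basis no step beyond the scatter is expected in this assay for compound 3, though the wider range reflects the lack of a matching comparison.

Compound 3 is therefore estimated at 9.4, with a range of 9 to 9.8. The step this implies, a number 0.07 log units lower from compound 1 to compound 3 (within the scatter), is expected to be negligible.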

Compound 3, acid dissociation constant: 9.28
Compound 3: middle estimate off by 0.12 log units, on the high side; low and high end bracket the measured number.
By their numbers in this assay, from the lowest: compounds 3, 1 and 2 (each within the scatter of the next).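

Among the compounds shown here, compound 3 gives the first reading at this aromatic carbon of the shared core, a site the earlier pair left untouched: in this assay, the change from cyclohexyl to 2-methoxyphenoxy gives a number 0.19 log units lower from compound 1 to compound 3 (within the scatter). The read-out therefore stays within the scatter even though the substituent goes from a six-membered non-aromatic ring of 6 heavy atoms with 0 hydrogen-bond acceptors to a six-membered aromatic ring of 9 heavy atoms with 2 hydrogen-bond acceptors, and this matches the replacement on the saturated chain carbon, no change at the digits printed from compound 1 to compound 2 (within the scatter), so each of the two sites has now taken one replacement without a step beyond the scatter. No supporting data bear on the reason for this flat result.

The compounds shown leave open whether a substituent of a different kind on this aromatic carbon, such as an amine or a carboxylic acid, would also stay within the scatter. They also leave open how a longer chain in place of the present saturated chain would read, and whether furan-2-yl and 2-methoxyphenoxy together would stay level in this assay.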